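Methoxy to Ethoxy: an Expected Step in Aortic Inhibition

A few compounds are considered here, and "the series" means these few. Any claim that something is new, unique, unknown or untested is made for them only; others in the source may bear on it.

Compound 1, `COc1nc(-c2cc3ccccc3o2)cc(-c2ccc(Br)cc2)c1C#N`: 298000 nM
Compound 2, `CCOc1nc(-c2cc3ccccc3o2)cc(-c2ccc(Br)cc2)c1C#N`: 227000 nM
Compound 3, `COc1cc(-c2cc(-c3cc4ccccc4o3)nc(OC)c2C#N)cc(OC)c1OC`: 310000 nM

Of the compounds shown here, three have been measured in a functional assay on aorta (strain Wistar) for inhibition, with Thoracic aorta (Rattus norvegicus) as the target; on this read-out lower numbers stand for stronger inhibition and higher numbers for weaker inhibition. Compound 2 differs from compound 1 by methyl in place of hydrogen on a saturated chain carbon bound to an oxygen on an aromatic ring, and this gave a 1.3-fold lower number from compound 1 to compound 2 (0.12 log units; within the scatter). Compound 3 carries a different core; the difference between the cores of compound 3 and compound 1 is not broken down here, and the values of compound 3 and compound 1 in this assay lie within the scatter of each other.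

Compound 4, `CCOc1nc(-c2cc3ccccc3o2)cc(-c2cc(OC)c(OC)c(OC)c2)c1C#N`, is not yet measured. It differs from compound 3 by methyl in place of hydrogen on a saturated chain carbon bound to an oxygen on an aromatic ring, the same change that turned compound 1 into compound 2. Because a 1.3-fold lower number from compound 1 to compound 2 (0.12 log units; within the scatter) was small, the expected step is a 1.3-fold lower number from compound 3 to compound 4 (0.11 log units; within the scatter). Compound 4 is therefore estimated at 240000 nM in this assay, between 120000 nM and 480000 nM.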

Compound 4, half-maximal inhibitory concentration: 365000 nM
The estimate for compound 4 lay 1.5-fold (0.18 log units) below the measured number, and the stated range covers the measured number.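

In this assay, methoxy to ethoxy on the second core gave a 1.2-fold higher number from compound 3 to compound 4 (0.07 log units; within the scatter). Set side by side, the two steps do not differ beyond what repeated measurement allows: the same change on two cores in this assay, a 1.3-fold lower number (0.12 log units; within the scatter) from compound 1 to compound 2 and a 1.2-fold higher number (0.07 log units; within the scatter) from compound 3 to compound 4, 1.5-fold (0.19 log units) apart, within the scatter of two such steps On these two cores the change thus left the read-out within the scatter each time, but this shows neither a real effect of the change in either direction nor that the same would hold on a third core.

The compounds shown leave open whether a longer chain such as propoxy, or a chain carrying an amine, in place of ethoxy would move the read-out beyond the scatter.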